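Chloro in Place of Cyano on the Shared Core

The source may hold more compounds than are shown below. What is called first, only, known or untested is meant among the compounds shown, and "the series" means these compounds.

Among the measured compounds shown here, compound 1 `CNc1nc(C#N)nc(NC2(C#N)CCCCC2)n1` holds the lowest of the two numbers measured so far; in an ADME assay on microsomes from liver (Rattus norvegicus) for metabolic stability (on this read-out higher numbers stand for fast clearance and lower numbers for slow clearance), compound 1 gives 122 mL/min/kg. Compound 2 `CNc1nc(NC2(C#N)CCCCCC2)nc(-n2cncn2)n1` in this assay gives 276 mL/min/kg, a value beyond the scatter above compound 1. Compound 3 `CNc1nc(Cl)nc(NC2(C#N)CCCCC2)n1` is not yet measured. It differs from compound 1 in one place: chloro in place of cyano on an aromatic carbon. For the measured compounds named here, no measured pair shows this change, so in this assay a step of no more than the usual scatter is expected, in either direction. The estimate for compound 3 in this assay is 140 mL/min/kg, with a range from 70 mL/min/kg to 280 mL/min/kg. The expected step is a 1.1-fold higher number from compound 1 to compound 3 (0.06 log units; within the scatter).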

Compound 3, clearance: 867 mL/min/kg
Beside the measured number, compound 3's estimate is 6.2-fold (0.79 log units) below it, outside the stated range (above it).
By their numbers in this assay, from the lowest: compound 1; then compound 2; then compound 3.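

In this assay chloro in place of cyano on this aromatic carbon gives a 7.1-fold higher number from compound 1 to compound 3 (0.85 log units; beyond the scatter) and so shows that clearance responds strongly to the group at this position on the shared core. Compound 2 could not show this, as it differs from compound 1 in more than one place. Nothing at hand accounts for the size of this step. Going by these compounds, whether a methoxy group, an amine or fluoro here would give clearance nearer to that of compound 1 or of compound 3 stays open.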